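Chloro on the anilino ring of compound 3

The compounds below may be only part of what the source reports. "The series", "measured", "known", "first", "only" and "open" are said of these compounds alone.

Compound 3, `CCOC(=O)CN(Cc1ccccc1)c1nc(Nc2ccccc2)ncc1[N+](=O)[O-]`, is measured in a functional assay on MDA-MB-231 cells (Homo sapiens) for antiproliferative activity, read by MTT assay, with a stated time of 48 h (on this read-out higher numbers stand for weaker inhibition and lower numbers for stronger inhibition), only as a limit, > 100000 nM, so it is known only where 1 of the 3 values shown sit: the limit of > 100000 nM in this assay, at which 1 of the 3 values shown sits. Within the data shown here, compound 1, `CCOC(=O)CN(Cc1ccccc1)c1nc(NCc2ccccc2)ncc1[N+](=O)[O-]`, gives 82400 nM; the step of an at least 1.2-fold higher number from compound 1 to compound 3 (0.08 log units; that floor lies within the scatter) is the only measured step touching compound 3 and does not concern the change now made. Compound 4, `CCOC(=O)CN(Cc1ccccc1)c1nc(Nc2ccc(Cl)cc2)ncc1[N+](=O)[O-]`, differs from compound 3 by chloro in place of hydrogen on an aromatic carbon. Among the measured compounds shown here, no measured step covers this change alone. Compound 2, `CCOC(=O)CNc1nc(Nc2ccc(Cl)cc2)ncc1[N+](=O)[O-]`, carries the same chloro but also a hydrogen in place of benzyl on the other nitrogen, and gives 55500 nM. Compound 4 is therefore expected near the limit, with an at least 1.1-fold lower number from compound 3 to compound 4 (0.04 log units; that floor lies within the scatter) as the estimated step and an estimate of 90000 nM (range 35000 nM to 250000 nM).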

Compound 4, half-maximal inhibitory concentration: 34400 nM
Estimate against measurement, compound 4: 2.6-fold (0.42 log units) above, and the stated range ends above it.
By their numbers in this assay, from the lowest: compounds 4, 2 and 1 (each within the scatter of the next, the first and the last beyond it). At a limit, above all of these: compound 3.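

Compound 3 is known only as a limit: the limit of > 100000 nM in this assay, at which 1 of the 4 values shown sits. Chloro in place of hydrogen on the anilino ring therefore gives only a floor, an at least 2.9-fold lower number from compound 3 to compound 4 (0.46 log units; beyond the scatter), yet this is the first sign in this assay that this place on the ring responds to a change. With the chloro kept, benzyl in place of hydrogen on a nitrogen gives a 1.6-fold lower number from compound 2 to compound 4 (0.21 log units; within the scatter), and 4-chlorophenyl in place of benzyl gives a 2.4-fold lower number from compound 1 to compound 4 (0.38 log units; beyond the scatter).

As far as these compounds go, whether fluoro, methoxy or an amine at the same place would act as chloro does remains open. So does the effect of a carboxylic acid in place of the ethyl ester.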